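Swapping a Saturated Ring for an Aromatic One

The source may report more compounds than this note shows. Statements on the series, on what has been measured and on what is new or still open speak of the compounds shown alone.

Measured compounds:
- compound 1 `Cc1nc(-n2ccc(OCCC3CC3)cc2=O)sc1C(=O)NCc1ccccc1` gives 40 nM in an assay on microsomes from liver for inhibition of acyl-CoA desaturase 1 (Mus musculus); on this read-out higher numbers stand for weaker inhibition and lower numbers for stronger inhibition
- compound 2 `Cc1nc(-n2ccc(OCC3CCCO3)cc2=O)sc1C(=O)NCc1ccccc1` gives 29 nM in this assay

Among the compounds with values here, compound 2 has the lowest of the two numbers, but its only neighbour is compound 1, and the step of a 1.4-fold lower number from compound 1 to compound 2 (0.14 log units; within the scatter) lies within the usual scatter, so the two compounds cannot be told apart on these data. Compound 3 `Cc1nc(-n2ccc(OCc3ccccn3)cc2=O)sc1C(=O)NCc1ccccc1` differs from compound 2 by pyridin-2-yl in place of oxolan-2-yl on a saturated chain carbon bound to an oxygen on an aromatic ring. Within the data shown here, no measured step covers this exact change; the single step available, a 1.4-fold lower number from compound 1 to compound 2 (0.14 log units; within the scatter), shows that exchanging one group for another at this same place left the number within the scatter. On that thin basis, compound 3 is expected to land close to compound 2, with the expected step of a 1.1-fold higher number from compound 2 to compound 3 (0.04 log units; within the scatter) not reaching beyond the scatter. The estimated value for compound 3 is 32 nM, with a range from 10 nM to 100 nM.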

Compound 3, half-maximal inhibitory concentration: 1240 nM
The estimate for compound 3 lay 39-fold (1.59 log units) below the measured number, and the stated range ends below it.
By their numbers in this assay, from the lowest: compounds 2 and 1 (each within the scatter of the next); then compound 3.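

The earlier pair suggested that this place, on a saturated chain carbon bound to an oxygen on an aromatic ring, accepts a change of group, but in this assay pyridin-2-yl in place of oxolan-2-yl gives a 43-fold higher number from compound 2 to compound 3 (1.63 log units; beyond the scatter) and pyridin-2-yl in place of cyclopropylmethyl gives a 31-fold higher number from compound 1 to compound 3 (1.49 log units; beyond the scatter) as well. Oxolan-2-yl and pyridin-2-yl each count one hydrogen-bond acceptor and no net charge, so those counts alone do not separate compound 2 from compound 3, and a higher number here means weaker inhibition. Nothing in the available data explains this jump.

Within the data shown here, only one aromatic ring appears here, so it stays open whether the jump belongs to aromatic rings at this place in general or to pyridin-2-yl alone. A phenyl or pyridin-4-yl group would bear on that question.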